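What a Dimethylamino Chain Might Do to Compound 3

The source may hold more compounds than are shown below. What is called first, only, known or untested is meant among the compounds shown, and "the series" means these compounds.

- Compound 1 `COc1ncc(-c2ccc3nc(NC(=O)N4CCCC4)nn3c2)cc1NS(=O)(=O)c1ccc(F)cc1`: 1690 nM
- Compound 2 `COc1ncc(-c2ccc3nc(NC(=O)N(C)C)nn3c2)cc1NS(=O)(=O)c1ccc(F)cc1`: 1780 nM
- Compound 3 `COc1ncc(-c2ccc3nc(NC(=O)NCC(=O)N4CCCC4)nn3c2)cc1NS(=O)(=O)c1ccc(F)cc1`: 1000 nM

In a functional assay on U-87MG ATCC cells for cytotoxicity against U-87 MG (Homo sapiens), read by MTT assay, with a stated time of 72 h (on this read-out lower numbers stand for stronger inhibition and higher numbers for weaker inhibition), compound 3 gives 1000 nM, which lies within the usual scatter of compound 1 and compound 2. Compound 4 `COc1ncc(-c2ccc3nc(NC(=O)NCCN(C)C)nn3c2)cc1NS(=O)(=O)c1ccc(F)cc1` differs from it in one place: (dimethylamino)methyl in place of (pyrrolidin-1-yl)carbonyl on a saturated chain carbon bound to an amide-type nitrogen. Put another way, 2-(dimethylamino)ethyl stands in place of ((pyrrolidin-1-yl)carbonyl)methyl. Among the measured compounds shown here, no measured step makes this exact swap. The closest evidence comes from changes on the same carbonyl carbon: a 1.1-fold higher number from compound 1 to compound 2 (0.02 log units; within the scatter), a 1.7-fold lower number from compound 1 to compound 3 (0.23 log units; within the scatter) and a 1.8-fold lower number from compound 2 to compound 3 (0.25 log units; within the scatter). All three stay within the scatter, so no step beyond the scatter is expected here, in either direction. The expected change is a 1.2-fold higher number from compound 3 to compound 4 (0.08 log units; within the scatter). In this assay the estimate for compound 4 is 1200 nM, with a range of 500 nM to 3000 nM.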

Compound 4, half-maximal inhibitory concentration: 980 nM
Compound 4: the middle estimate sits 1.2-fold (0.09 log units) above what was measured, within the range that was stated.
By their numbers in this assay, from the lowest: compounds 4, 3, 1 and 2 (each within the scatter of the next).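

Replacing (pyrrolidin-1-yl)carbonyl with (dimethylamino)methyl on this saturated chain carbon gives a 1.0-fold lower number from compound 3 to compound 4 (0.01 log units; within the scatter), so here a chain with no ring and no carbonyl reads the same as the ring-bearing one. With (2-(dimethylamino)ethyl)amino on the carbonyl carbon, the comparisons with the shorter groups give a 1.8-fold lower number from compound 2 to compound 4 (0.26 log units; within the scatter) and a 1.7-fold lower number from compound 1 to compound 4 (0.24 log units; within the scatter), so this chain shows no real gain over either. Going by these compounds, whether a carboxylic acid or a longer chain at this place would move the number beyond the scatter stays open. Nothing available explains these numbers.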